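The compounds below may be only part of what the source reports. "The series", "measured", "known", "first", "only" and "open" are said of these compounds alone.

Compound 1 `Cc1cc(C)nc(Oc2ccc(NC(=O)Nc3ccc(OC(F)(F)F)cc3)cc2)n1`, compound 2 `Cc1cc(C)nc(Oc2ccc(NC(=O)Nc3ccc(F)cc3)cc2)n1` and compound 3 `Cc1cc(C)nc(Sc2ccc(NC(=O)Nc3ccc(OC(F)(F)F)cc3)cc2)n1` have been measured in a functional assay on CNE-2 cells (Homo sapiens) for cytotoxicity, read by MTT assay, with a stated time of 3 days; a higher number here means a weaker inhibitor, a lower number a stronger inhibitor. In this assay compound 1 gives 30800 nM, compound 2 gives 46900 nM and compound 3 gives 22800 nM. The change between compound 1 and compound 2 is fluoro in place of trifluoromethoxy on an aromatic carbon. In this assay this gave a 1.5-fold higher number from compound 1 to compound 2 (0.18 log units; within the scatter). The two cores differ by (4,6-dimethylpyrimidin-2-yl)sulfanyl in place of (4,6-dimethylpyrimidin-2-yl)oxy on an aromatic carbon, and in this assay that gave a 1.4-fold lower number from compound 1 to compound 3 (0.13 log units; within the scatter). Compound 4 `Cc1cc(C)nc(Sc2ccc(NC(=O)Nc3ccc(F)cc3)cc2)n1` is not yet measured. From compound 3 to compound 4 the change is fluoro in place of trifluoromethoxy on an aromatic carbon; this is the same change as the one made on compound 1, now made on the core of compound 3, and among these compounds it occurs twice. Among the measured compounds shown here, the only guide to its size is the step of a 1.5-fold higher number from compound 1 to compound 2 (0.18 log units; within the scatter), so the step in this assay from compound 3 to compound 4 is expected to be of about that size, a 1.5-fold higher number from compound 3 to compound 4 (0.17 log units; within the scatter), resting on that single pair. On this basis compound 4 is estimated at 34000 nM in this assay, with a plausible range from 20000 nM to 60000 nM.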

Compound 4, half-maximal inhibitory concentration: 34100 nM
Compound 4: middle estimate off by 1.0-fold (0.00 log units), on the low side; the measured number falls inside the stated range.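

In this assay, fluoro in place of trifluoromethoxy gives a 1.5-fold higher number from compound 3 to compound 4 (0.17 log units; within the scatter), and the step carries from one core to the other with no difference in size: the same change on two cores in this assay, a 1.5-fold higher number (0.18 log units; within the scatter) from compound 1 to compound 2 and a 1.5-fold higher number (0.17 log units; within the scatter) from compound 3 to compound 4, 1.0-fold (0.01 log units) apart, within the scatter of two such steps. Both steps lie within the scatter, so the agreement concerns a change too small to read on its own, and neither step shows that fluoro and trifluoromethoxy truly differ in this assay. Among the compounds shown here, the oxy and sulfanyl cores give only one comparison, which does not show whether the step would hold on a core differing elsewhere, or whether a larger step would carry across in the same way.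

Going by these compounds, it remains open whether any group on this aromatic carbon moves the number beyond the scatter, for example an amine, a carboxylic acid or a longer chain in place of fluoro. On these data alone, it is also open how the series responds when the 4,6-dimethylpyrimidin-2-yl group itself is exchanged for another group.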